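A few compounds are considered here, and "the series" means these few. Any claim that something is new, unique, unknown or untested is made for them only; others in the source may bear on it.

Measured in a functional assay on A549 cells (Homo sapiens) for inhibition, read by MTT assay, with a stated time of 72 h; a higher number here means a weaker inhibitor, a lower number a stronger inhibitor:
Compound 1 `C=C(Cl)C(=O)Nc1cc(Nc2nc3c(c(-c4cn(C)c5ccccc45)n2)CS(=O)(=O)CC3)c(OC)cc1N(C)CCN(C)C`: 881 nM
Compound 2 `C=CC(=O)Nc1cc(Nc2nc3c(c(-c4cn(C)c5ccc(F)cc45)n2)CS(=O)(=O)CC3)c(OC)cc1N(C)CCN(C)C`: 4640 nM

Of these two, compound 2 stands higher, at 4640 nM, which makes it the weaker inhibitor, and its gap to compound 1 lies beyond the usual scatter. The two compounds differ in more than one place, so that gap cannot be pinned on a single change.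

Compound 3 `C=C(Cl)C(=O)Nc1cc(Nc2nc3c(c(-c4cn(C)c5ccc(F)cc45)n2)CS(=O)(=O)CC3)c(OC)cc1N(C)CCN(C)C`, not yet measured, departs from compound 2 in one place: chloro in place of hydrogen on a double-bonded chain carbon bound to a carbonyl carbon. For the measured compounds named here, no measured pair isolates this change. Compound 1 already carries the same ((1-chloroethenyl)carbonyl)amino group and gives 881 nM, which points towards lower numbers in this assay. The expected step of a 2.9-fold lower number from compound 2 to compound 3 (0.46 log units; beyond the scatter) is therefore moderate and towards a stronger inhibitor. For compound 3 the estimated value is 1600 nM, with an expected range of 600 nM to 4500 nM.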

Compound 3, half-maximal inhibitory concentration: 3180 nM
For compound 3 the middle estimate is 2.0-fold (0.30 log units) below the measured one; the measured number falls inside the stated range.
By their numbers in this assay, from the lowest: compound 1; then compounds 3 and 2 (each within the scatter of the next).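

In this assay, placing chloro in place of hydrogen on a double-bonded chain carbon bound to a carbonyl carbon gives a result within the scatter (a 1.5-fold lower number from compound 2 to compound 3 (0.16 log units; within the scatter)), so this change does not separate these two fluoro-bearing compounds. The earlier gap between compound 1 and compound 2 therefore cannot be read as a simple chloro effect, as fluoro in place of hydrogen on an aromatic carbon moves the number beyond the scatter (a 3.6-fold higher number from compound 1 to compound 3 (0.56 log units; beyond the scatter)), towards a weaker inhibitor. Nothing measured here explains either step.

From the compounds shown here alone, whether the chloro change would behave the same way without the fluoro group remains open. So does how a bromo or methyl group would read at the chain carbon, or a methoxy group at the aromatic carbon.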